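Methoxy for Chloro on the Benzoic Acid Ring

The source may hold more compounds than are shown below. What is called first, only, known or untested is meant among the compounds shown, and "the series" means these compounds.

Of the compounds shown here, three built on one shared core have been measured in an assay for positive allosteric modulation of metabotropic glutamate receptor 2 (Rattus norvegicus); a lower number here means that less compound is needed, a higher number that more compound is needed for the effect. Compound 1 `COc1cc(C(=O)O)ccc1OC[C@H](C)COc1ccc(C(=O)CC(C)(C)C)c(O)c1C` gives 28 nM, compound 2 `Cc1c(OC[C@@H](C)COc2ccc(C(=O)O)cc2Cl)ccc(C(=O)CC(C)(C)C)c1O` gives 477 nM, and compound 3 `Cc1c(OC[C@@H](C)COc2ccc(C(=O)O)c(Cl)c2)ccc(C(=O)CC(C)(C)C)c1O` gives 50 nM. Compound 2 and compound 3 differ only in how the same atoms are joined: 4-carboxy-3-chlorophenyl in place of 4-carboxy-2-chlorophenyl on an oxygen on a saturated carbon Moving the chloro in this way gives a 9.5-fold lower number from compound 2 to compound 3 (0.98 log units; beyond the scatter). Compound 1 and compound 3 lie within the usual scatter of each other, so no order between them can be claimed.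

The change from compound 2 to compound 1 is methoxy in place of chloro on an aromatic carbon It made a 17-fold lower number from compound 2 to compound 1 (1.23 log units; beyond the scatter), the largest step among these three compounds.

Compound 4 `COc1cc(OC[C@H](C)COc2ccc(C(=O)CC(C)(C)C)c(O)c2C)ccc1C(=O)O` has not yet been measured. Among the measured compounds shown here, it differs from compound 3 by methoxy in place of chloro on an aromatic carbon This is the same kind of change as the one from compound 2 to compound 1, but not the same: in compound 1 the methoxy sits ortho to a large group and meta to a carboxy group, whereas in compound 4 it sits ortho to a carboxy group and meta to a large group. Because a 17-fold lower number from compound 2 to compound 1 (1.23 log units; beyond the scatter) was large and compound 3 already gives 50 nM, a gain is expected for compound 4, though a smaller one: its step is estimated at a 2.0-fold lower number from compound 3 to compound 4 (0.30 log units; within the scatter). Compound 4 is thus expected at 25 nM, with a range from 8 nM to 80 nM.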

Compound 4, half-maximal effective concentration: 194 nM
The estimate for compound 4 lay 7.8-fold (0.89 log units) below the measured number; the measured number lies above the stated range.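

In this assay, putting methoxy in place of chloro on the core of compound 3 gave a 3.9-fold higher number from compound 3 to compound 4 (0.59 log units; beyond the scatter), so the change did not repeat the gain it brought on the core of compound 1. The two results run in opposite directions, and the gap between them is larger than repeated measurements would explain: the same change on two cores in this assay, a 17-fold lower number (1.23 log units; beyond the scatter) from compound 2 to compound 1 and a 3.9-fold higher number (0.59 log units; beyond the scatter) from compound 3 to compound 4, 66-fold (1.82 log units) apart, beyond the scatter of two such steps

This shows that, in this series, the result of exchanging chloro for methoxy at one place on the benzoic acid ring cannot simply be carried over to another place, here ortho to a carboxy group and meta to a large group; it does not show why the two steps part, and two pairs of compounds give no general rule for this change in either direction.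

The compounds shown leave open whether a different small group at the same place, such as fluoro, methyl or hydroxy, would follow the result for chloro or the one for methoxy. They also leave open whether the same reversal would appear with a longer chain joining the two aromatic rings or with a nitrile in place of the carboxy group.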